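This account rests on a few compounds, and the source may have more. Where it says the series, first, only, none or still open, it means among the compounds named here.

Measured in an ADME assay on J774.A1 cells (Mus musculus) for inhibition, read by MTT assay, with a stated time of 72 h; a higher number here means that more compound is needed for the effect, a lower number that less compound is needed:
- Compound 1 `COc1ccc(CNc2nc(NCc3ccccc3)nc3ccccc23)cc1`: 5200 nM
- Compound 2 `COc1ccc(CNc2nc(NCc3ccc(OC)cc3)c3ccccc3n2)cc1`: 2200 nM

Compound 1 has the higher number of the two, so more of it is needed for the effect. Compound 3 `CC(C)Nc1nc(NCc2ccccc2)nc2ccccc12` has not yet been measured. It arises from compound 1 through one change: isopropyl in place of 4-methoxybenzyl on a nitrogen on an aromatic ring. In words, isopropyl takes the place of 4-methoxybenzyl on a nitrogen on an aromatic ring.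

Going by the values given here, only one measured step bears on this, and only loosely. With methoxy in place of hydrogen on an aromatic carbon, the number fell modestly, a 2.4-fold lower number from compound 1 to compound 2 (0.37 log units; beyond the scatter). Among the compounds with values here, compound 3 loses a methoxy rather than gaining one, so a modest move to a higher number is expected, though no measured step makes a swap like this one. The expected step is a 1.7-fold higher number from compound 1 to compound 3 (0.24 log units; within the scatter). For compound 3 the estimated value is 9000 nM, with an expected range of 3000 nM to 25000 nM.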

Compound 3, half-maximal effective concentration: 7200 nM
For compound 3 the middle estimate is 1.3-fold (0.10 log units) above the measured one; the measured number falls inside the stated range.
By their numbers in this assay, from the lowest: compound 2; then compounds 1 and 3 (each within the scatter of the next).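

In this assay, putting isopropyl in place of 4-methoxybenzyl on a nitrogen on an aromatic ring gives a 1.4-fold higher number from compound 1 to compound 3 (0.14 log units; within the scatter) and so no real difference can be claimed between the two compounds. This is a large change in structure: 9 heavy atoms, including a six-membered aromatic ring and an oxygen, give way to 3 carbon atoms with no ring, yet the reading stays within the usual spread of repeated measurements. No measured information on the compounds accounts for this result.

Still open, from the compounds shown here alone, is whether a quite different group on this nitrogen, such as a longer chain ending in an amine or a carboxylic acid, would move the number beyond the scatter. A single pair also cannot show whether a plain methyl would behave like isopropyl here.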